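Removing a Methyl from an Aryl Ether: Expected Growth Effect

The source may report more compounds than this note shows. Statements on the series, on what has been measured and on what is new or still open speak of the compounds shown alone.

Measured compounds:
compound 1 `O=C(Nc1cccc(-n2cc(-c3ccncc3)c(-c3ccc(Cl)c(O)c3)n2)c1)Nc1cccc(C(F)(F)F)c1` – > 32500 nM
compound 2 `O=C(Nc1cccc(-n2cc(-c3ccncc3)c(-c3ccc(Cl)c(O)c3)n2)c1)Nc1ccc(Cl)c(Cl)c1` – > 32500 nM
compound 3 `COc1cc(-c2nn(-c3cccc(NC(=O)Nc4ccc(Cl)c(C(F)(F)F)c4)c3)cc2-c2ccncc2)ccc1Cl` – 3250 nM

Going by the values given here, in a functional assay on RPMI-8226 cells (Homo sapiens) for inhibition, read by sulforhodamine B assay, with a stated time of 48 h (a higher number here means a weaker inhibitor of growth, a lower number a stronger inhibitor of growth), compound 3 gives 3250 nM, the only value that is an actual number. For compound 1 the result is a limit of the assay, > 32500 nM. For compound 2 the result is likewise a limit, > 32500 nM. The step that the two limits leave unreadable from compound 1 to compound 2 therefore cannot be read. Compound 4 `O=C(Nc1cccc(-n2cc(-c3ccncc3)c(-c3ccc(Cl)c(O)c3)n2)c1)Nc1ccc(Cl)c(C(F)(F)F)c1` differs from compound 3 by hydrogen in place of methyl on an oxygen on an aromatic ring. Among the compounds with values here, no measured step covers this change; the two compounds carrying the hydroxy group both sit at the limit of > 32500 nM in this assay, at which 2 of the 3 values shown sit, yet their urea aryl groups also differ from that of compound 4, so no pattern follows. The step of a 3.7-fold higher number from compound 3 to compound 4 (0.57 log units; beyond the scatter) is estimated toward weaker inhibition with wide uncertainty. Compound 4 is expected near 12000 nM, between 3500 nM and 40000 nM.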

Compound 4, concentration for total growth inhibition: 2000 nM
For compound 4 the middle estimate is 6.0-fold (0.78 log units) above the measured one, and the stated range ends above it.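

In this assay the swap of methoxy for hydroxy on this aromatic ring gives a 1.6-fold lower number from compound 3 to compound 4 (0.21 log units; within the scatter) and so makes no real difference here. The hydroxy compounds can still differ widely through the other aryl group of the urea: an at least 16-fold lower number from compound 2 to compound 4 (1.21 log units; beyond the scatter) comes with trifluoromethyl in place of chloro, and an at least 16-fold lower number from compound 1 to compound 4 (1.21 log units; beyond the scatter) comes with chloro in place of hydrogen. Compound 1 and compound 2 each stand at a limit of the assay, not a number: the limit of > 32500 nM in this assay, at which 2 of the 4 values shown sit.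

On these data alone, what an ethyl group or a longer chain on this oxygen would do remains open. So does the effect of an amine in place of the hydroxy group.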